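Aryl sulfonamide variation on the shared core

The source may report more compounds than this note shows. Statements on the series, on what has been measured and on what is new or still open speak of the compounds shown alone.

Compound 1 `Cc1cccc(S(=O)(=O)NCc2ccc(C(=O)Nc3cccnc3)cc2)c1` carries 3-methylphenyl on the sulfonyl sulfur. In a functional assay on RCC4 cells (Homo sapiens) for cytotoxicity, read by XTT assay, with a stated time of 4 days (a higher number here means a weaker inhibitor, a lower number a stronger inhibitor), compound 1 gives < 1000 nM, which is a limit of the assay rather than a number. Compound 2 `Cn1ccc(-c2cccc(S(=O)(=O)NCc3ccc(C(=O)Nc4cccnc4)cc3)c2)n1` in this assay likewise gives only the limit < 1000 nM. The step that the two limits leave unreadable from compound 1 to compound 2 stays unreadable because the limit of < 1000 nM in this assay, at which 2 of the 2 values shown sit, holds both values. Compound 3 `COc1ccc(S(=O)(=O)NCc2ccc(C(=O)Nc3cccnc3)cc2)cc1OC` differs from compound 1 by 3,4-dimethoxyphenyl in place of 3-methylphenyl on a sulfonyl sulfur. For the measured compounds named here, no measured step gives a readable size for this kind of change, so the expected step that the limit leaves unreadable from compound 1 to compound 3 is set close to flat. Compound 3 is accordingly expected near 400 nM, within 60 nM to 2000 nM, quite possibly again reported only as a limit.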

Compound 3, half-maximal inhibitory concentration: < 1000 nM
Compound 3: no number, only a limit; the forecaster's own chance of this, stated with the estimate: 65%; the middle value does not contradict the limit.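

For the compounds shown here, no step among compound 1, compound 2 and compound 3 can be read in this assay, since each result is a limit and not a number: the limit of < 1000 nM in this assay, at which 3 of the 3 values shown sit. On these data alone, the actual potency of these three compounds, and whether the group on the sulfonyl sulfur matters, remains open.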